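The source may report more compounds than this note shows. Statements on the series, on what has been measured and on what is new or still open speak of the compounds shown alone.

Measured so far in a functional assay on MCF7 cells (Homo sapiens) for antiproliferative activity, read by sulforhodamine B assay, with a stated time of 48 h; a lower number here means a stronger inhibitor, a higher number a weaker inhibitor:
- compound 1 `O=C1NCCN1c1ccc(S(=O)(=O)Nc2ccc3[nH]ccc3c2)cc1` at 170 nM
- compound 2 `Cc1cccc(NS(=O)(=O)c2ccc(N3CCNC3=O)cc2)c1` at 190 nM

Compound 2 stands level with compound 1, the two values lying within the scatter of each other. Compound 3 `O=C1NCCN1c1ccc(S(=O)(=O)Nc2ccc(F)cc2)cc1` has not yet been measured. Relative to compound 2, it carries 4-fluorophenyl in place of 3-methylphenyl on a sulfonamide nitrogen. Among the measured compounds shown here, no measured step isolates this change. Compound 1 and compound 2 carry different groups on the sulfonamide nitrogen, yet compound 2 at 190 nM sits within the scatter of compound 1 at 170 nM in this small set. Only a modest move toward a weaker inhibitor is therefore expected, and its direction has little support from the data. The expected step is a 1.7-fold higher number from compound 2 to compound 3 (0.23 log units; within the scatter) as an estimate only. For compound 3 the expected value in this assay is 320 nM with 90 nM to 1200 nM as the estimated range.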

Compound 3, half-maximal inhibitory concentration: 690 nM
Compound 3: the middle estimate sits 2.2-fold (0.33 log units) below what was measured; measured number inside the range.
By their numbers in this assay, from the lowest: compounds 1 and 2 (each within the scatter of the next); then compound 3.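

In this assay, 4-fluorophenyl in place of 3-methylphenyl on a sulfonamide nitrogen gives a 3.6-fold higher number from compound 2 to compound 3 (0.56 log units; beyond the scatter), so the potency at this position depends on which aryl group it carries, which the level values of compound 1 and compound 2 did not reveal. The two groups have the same heavy-atom count and each is one six-membered aromatic ring, so the step comes without any change in either feature. Nothing available bears on the reason for the step.

Going by these compounds, whether the step follows the exchange of methyl for fluorine or the different ring placement remains open, and 3-fluorophenyl or 4-methylphenyl would separate the two. Also open, on these data alone, is how a phenyl ring carrying an amine or a carboxylic acid would read in this assay.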